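The source may report more compounds than this note shows. Statements on the series, on what has been measured and on what is new or still open speak of the compounds shown alone.

In an assay on isolated protein for displacement of a labelled ligand from 5-hydroxytryptamine receptor 6 (Homo sapiens) (on this read-out lower numbers stand for stronger inhibition and higher numbers for weaker inhibition), compound 3 `CN(C)S(=O)(=O)NC[C@@H]1CCCc2cc(S(=O)(=O)c3cccc(F)c3)ccc21` gives 2 nM. That number is level with compound 2 `NC[C@@H]1CCCc2cc(S(=O)(=O)c3cn[nH]c3)ccc21`, which gives 2 nM, and the two together are the highest of the three; compound 1 `CNC[C@@H]1CCCc2cc(S(=O)(=O)c3cc[nH]c3)ccc21` gives 0.159 nM, a much lower number, beyond the scatter. Compound 4 `O=S(=O)(c1cccc(F)c1)c1ccc2c(c1)CCC[C@H]2CNCCO` has not yet been measured. It differs from compound 3 in one place: 2-hydroxyethyl in place of dimethylsulfamoyl on an amine nitrogen. For the measured compounds named here, no pair of measured compounds carries this same change, so the expectation rests on the spread of the set as a whole. For compound 4 a moderate step downward is expected, a 2.5-fold lower number from compound 3 to compound 4 (0.40 log units; beyond the scatter), since compound 1 gives 0.159 nM with a different group on that nitrogen. Compound 4 is expected to give 0.8 nM, with a range from 0.2 nM to 3 nM.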

Compound 4, inhibition constant: 0.126 nM
Compound 4: middle estimate off by 6.3-fold (0.80 log units), on the high side, and the stated range ends above it.
By their numbers in this assay, from the lowest: compounds 4 and 1 (each within the scatter of the next); then compounds 2 and 3 (each within the scatter of the next).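

In this assay, for the compounds shown here, 2-hydroxyethyl in place of dimethylsulfamoyl on the amine nitrogen gives a 16-fold lower number from compound 3 to compound 4 (1.20 log units; beyond the scatter), the first one-place step in this set. It shows that the group on this nitrogen can shift the read-out far beyond the scatter with the rest of the molecule unchanged, and that the sulfamoyl group can be replaced by a chain of fewer heavy atoms without any loss. Nothing available explains the size of this step. The compounds shown leave open whether the hydroxyl or the two-carbon chain carries the change. A plain ethyl, a 2-methoxyethyl or a longer 3-hydroxypropyl group on this nitrogen would separate these.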